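A Third Methoxy Added to the Core of Compound 2

The compounds below may be only part of what the source reports. "The series", "measured", "known", "first", "only" and "open" are said of these compounds alone.

Among the measured compounds shown here, in a functional assay on HT-29 cells (Homo sapiens) for inhibition, read by sulforhodamine B assay, with a stated time of 48 h (on this read-out higher numbers stand for weaker inhibition of growth and lower numbers for stronger inhibition of growth), compound 2 `COc1ccc(/C=C/C2CC=CC(=O)O2)cc1OC` gives 17.2 uM, the second highest of the three numbers measured so far. Compound 3 `COc1cc(/C=C/C2CC=CC(=O)O2)cc(OC)c1OC` gives 18.8 uM in this assay, and compound 1 `COc1ccc(/C=C/C2CC=CC(=O)O2)c(OC)c1` gives 6.6 uM, a lower number than compound 2. Compound 4 `COc1cc(OC)c(OC)cc1/C=C/C1CC=CC(=O)O1` has not yet been measured; it differs from compound 2 by methoxy in place of hydrogen on an aromatic carbon. For the measured compounds named here, only one measured step is of the same kind, a 1.1-fold higher number from compound 2 to compound 3 (0.04 log units; within the scatter), which also placed a methoxy in place of hydrogen on an aromatic carbon and left the number within the scatter. On that basis, no step beyond the scatter is expected from compound 2 to compound 4 in this assay, and the expected step is a 1.0-fold lower number from compound 2 to compound 4 (0.01 log units; within the scatter). Compound 4 is therefore estimated at 17 uM in this assay, with a range from 8 uM to 36 uM. Going by the values given here, this estimate rests on compound 2 alone, because compound 2 gives 17.2 uM and the only comparable change did not move the number.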

Compound 4, concentration for growth inhibition (reported as GI): 15.9 uM
Estimate against measurement, compound 4: 1.1-fold (0.03 log units) above; the measured number falls inside the stated range.
By their numbers in this assay, from the lowest: compound 1; then compounds 4, 2 and 3 (each within the scatter of the next).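

In this assay, a methoxy on the aromatic carbon ortho to a group of 9 heavy atoms leaves compound 2 within the scatter, a 1.1-fold lower number from compound 2 to compound 4 (0.03 log units; within the scatter), so a second position on this core takes the added group without a step that can be told apart. The same change made on compound 1 does give a readable step, a 2.4-fold higher number from compound 1 to compound 4 (0.38 log units; beyond the scatter), so the added methoxy goes with modestly weaker inhibition of growth on that core. Even so, the two cores cannot be told apart by the size of this change: the same change on two cores in this assay, a 1.1-fold higher number (0.04 log units; within the scatter) from compound 2 to compound 3 and a 2.4-fold higher number (0.38 log units; beyond the scatter) from compound 1 to compound 4, 2.2-fold (0.34 log units) apart, within the scatter of two such steps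

As far as these compounds go, only hydrogen and methoxy are compared at this position, so it remains open whether a hydroxyl, a chlorine or an amine there would move the number. From the compounds shown here alone, it also remains open whether the step from compound 1 would hold in other cell types.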